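Removing a phenolic hydroxy from a methoxy-bearing flavanonol

The source may hold more compounds than are shown below. What is called first, only, known or untested is meant among the compounds shown, and "the series" means these compounds.

The shared core is carried by compound 1 `O=C1c2ccc(O)c(O)c2O[C@@H](c2cccc(O)c2O)[C@@H]1O`, compound 2 `COc1ccc2c(c1O)O[C@@H](c1cccc(O)c1O)[C@H](O)C2=O` and compound 3 `COc1cc(OC)c2c(c1)OC(c1cccc(O)c1O)C(O)C2=O`. In a functional assay on RAW264.7 cells (Rattus norvegicus) for inhibition, with RAW264.7 (Mus musculus) as the target, read by Griess assay, with stated times of 2 h and 16 h (on this read-out higher numbers stand for weaker inhibition and lower numbers for stronger inhibition), compound 1 reaches only the limit of the measurement, > 100000 nM. In this assay compound 2 gives 88500 nM and compound 3 gives 57600 nM. Among the two numbers, compound 2 stands highest, with compound 3 nearest to it and within the scatter; the remaining value is a limit. Within the data shown here, the only step between compounds differing in one place, an at least 1.1-fold lower number from compound 1 to compound 2 (0.05 log units; that floor lies within the scatter), is a methyl in place of hydrogen on an oxygen on an aromatic ring, and it sits at the limit of > 100000 nM in this assay, at which 1 of the 3 values shown sits, of compound 1, so its true size is unknown.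

Compound 4 `COc1ccc2c(c1)O[C@@H](c1cccc(O)c1O)[C@H](O)C2=O` differs from compound 2 by hydrogen in place of hydroxy on an aromatic carbon, a hydrogen in place of hydroxy on an aromatic carbon of a six-membered aromatic ring of carbon only, part of a fused system of two rings, ortho to a fused ring and ortho to a methoxy group. Among the measured compounds shown here, no measured step covers the loss of a hydroxy, and the one step available is bounded by a limit, so in this assay no step beyond the scatter is expected. Compound 4 is therefore estimated at 85000 nM, within 35000 nM to 200000 nM, the expected step being a 1.0-fold lower number from compound 2 to compound 4 (0.02 log units; within the scatter).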

Compound 4, half-maximal inhibitory concentration: 30300 nM
For compound 4 the middle estimate is 2.8-fold (0.45 log units) above the measured one, outside the stated range (below it).
By their numbers in this assay, from the lowest: compounds 4, 3 and 2 (each within the scatter of the next, the first and the last beyond it). At a limit, above all of these: compound 1.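

In this assay, among these compounds, the hydroxy on the aromatic carbon ortho to a methoxy group and ortho to a fused ring gives the first change with a readable size, and hydrogen in its place yields a 2.9-fold lower number from compound 2 to compound 4 (0.47 log units; beyond the scatter) on the side of stronger inhibition. Among the compounds shown here, with the methoxy group kept, this hydroxy is therefore not required for the inhibition seen with the shared core, and its loss moves the number beyond the scatter, which the only earlier step could not show. That earlier step ends at the limit of compound 1 and cannot be read as a size: the limit of > 100000 nM in this assay, at which 1 of the 4 values shown sits. No measurement shown here gives a reason for the gain in inhibition.

On these data alone, what remains open is whether another group at this position, such as an amine, a fluorine atom or a carboxylic acid, would move the number further than hydrogen does. As far as these compounds go, it is also open whether replacing this hydroxy with hydrogen gives a step of similar size when the neighbouring methoxy group is replaced by a longer chain such as ethoxy.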